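This account rests on a few compounds, and the source may have more. Where it says the series, first, only, none or still open, it means among the compounds named here.

Series notes: hydrazine-containing core carrying a 1-benzofuran-2-yl group and a (pyridin-4-yl)carbonyl group, varied at one saturated ring carbon.

Compound 2 (`O=C(c1ccncc1)N1N=C(c2cc3ccccc3o2)CC1c1cccc([N+](=O)[O-])c1`) gives only a limit in an ADME assay on Vero cells (Chlorocebus sabaeus) for cytotoxicity, read by MTT assay, with a stated time of 72 h; on this read-out lower numbers stand for stronger inhibition and higher numbers for weaker inhibition; the value recorded for compound 2 is > 240000 nM, a limit of the assay and not a number. Compound 1 (`COc1ccccc1C1CC(c2cc3ccccc3o2)=NN1C(=O)c1ccncc1`) likewise gives a limit in this assay; compound 1 is recorded as > 202000 nM. Going by the values given here, the one measured step, a step that the two limits leave unreadable from compound 1 to compound 2, cannot be sized because both ends sit at limits, as the two limit lines show (the limit of > 202000 nM in this assay, at which 1 of the 2 values shown sits, and (the limit of > 240000 nM in this assay, at which 1 of the 2 values shown sits)).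

Compound 3 (`O=C(c1ccncc1)N1N=C(c2cc3ccccc3o2)CC1c1ccc(O)cc1`) is to be measured in this assay. Against compound 2 it differs in one place: 4-hydroxyphenyl in place of 3-nitrophenyl on a saturated ring carbon.

No readable step bears on this change; both measured compounds of the series sit at limits in this assay, so no direction beyond the scatter can be derived. The expectation for compound 3 is that it also sits at a limit, and the step of an at least 1.2-fold lower number from compound 2 to compound 3 (0.07 log units; that floor lies within the scatter) is estimated as none beyond the scatter. Compound 3 is therefore expected at about 200000 nM, within a range from 50000 nM to 500000 nM.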

Compound 3, half-maximal inhibitory concentration: > 200000 nM
Compound 3: no number, only a limit; the forecaster's own chance of this, stated with the estimate: 85%; the middle value sits exactly at the limit.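

In this assay compound 3 gives > 200000 nM, a limit of the assay and not a number. The steps from compound 1 and compound 2 to compound 3 cannot be read, since all three values are limits. The compounds shown leave open whether any group on the saturated ring carbon gives a measurable value, and how the 2-methoxyphenyl, 3-nitrophenyl and 4-hydroxyphenyl compounds truly compare.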